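Aryl hydrazone variation on the shared core: cytotoxicity notes

The source may report more compounds than this note shows. Statements on the series, on what has been measured and on what is new or still open speak of the compounds shown alone.

Compound 1 `CN(C)CCn1cnnc1-c1cc(Oc2ccc(NC(=O)N/N=C/c3cccc(Cl)c3Cl)cc2F)ccn1` gives 13200 nM in a functional assay on U-87MG ATCC cells (Homo sapiens) for cytotoxicity, read by MTT assay, with a stated time of 72 h (a higher number here means a weaker inhibitor, a lower number a stronger inhibitor), the higher of the two numbers in the set. Compound 2 `Cc1cc(/C=N/NC(=O)Nc2ccc(Oc3ccnc(-c4nncn4CCN(C)C)c3)c(F)c2)cc(C)c1O` gives 7710 nM; the change of a 1.7-fold lower number from compound 1 to compound 2 (0.23 log units; within the scatter) is not distinguished from repeat scatter. Compound 3 `CN(C)CCn1cnnc1-c1cc(Oc2ccc(NC(=O)N/N=C/c3c(Cl)cccc3Cl)cc2F)ccn1` reaches only the limit > 100000 nM in this assay, which is the limit of > 100000 nM in this assay, at which 1 of the 3 values shown sits. From compound 1 the step of an at least 7.5-fold higher number from compound 1 to compound 3 (0.87 log units; beyond the scatter), and from compound 2 the step of an at least 12-fold higher number from compound 2 to compound 3 (1.11 log units; beyond the scatter), both show that the arrangement of substituents on the phenyl attached to the carbon with a double bond to nitrogen can weaken the series sharply.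

Compound 4 `CN(C)CCn1cnnc1-c1cc(Oc2ccc(NC(=O)N/N=C/c3ccc(F)cc3F)cc2F)ccn1` carries 2,4-difluorophenyl in place of 2,3-dichlorophenyl on a carbon with a double bond to nitrogen. Within the data shown here, two measured steps bear on this site: one neutral, one strongly adverse, so the direction for a new halogen pattern is uncertain. With only these two precedents, the expectation for a 1.5-fold higher number from compound 1 to compound 4 (0.18 log units; within the scatter) is a small loss, possibly none beyond scatter. Compound 4 is therefore estimated at 20000 nM, within 7000 nM to 70000 nM.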

Compound 4, half-maximal inhibitory concentration: 1900 nM
Estimate against measurement, compound 4: 11-fold (1.02 log units) above, outside the stated range (below it).
By their numbers in this assay, from the lowest: compound 4; then compounds 2 and 1 (each within the scatter of the next). At a limit, above all of these: compound 3.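

In this assay, the position on a carbon with a double bond to nitrogen now shows a real gain, where earlier changes there were neutral or adverse: a 6.9-fold lower number from compound 1 to compound 4 (0.84 log units; beyond the scatter), and a 4.1-fold lower number from compound 2 to compound 4 (0.61 log units; beyond the scatter). Two halogens on the phenyl do not by themselves set the direction, as 2,4-difluorophenyl in place of 2,6-dichlorophenyl gives an at least 52-fold lower number from compound 3 to compound 4 (1.72 log units; beyond the scatter). The size of that step has no upper bound, as compound 3 is recorded only as a limit and not a number: the limit of > 100000 nM in this assay, at which 1 of the 4 values shown sits.

On these data alone, whether the gain follows the fluorine atoms or their arrangement stays open, as 2,4-difluorophenyl differs from 2,3-dichlorophenyl in both. Also open, as far as these compounds go, is how a phenyl carrying an amine or a carboxylic acid would read at this position.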